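Swapping 3,4-dichlorophenyl for 2-phenylethenyl at a cytotoxicity limit

A few compounds are considered here, and "the series" means these few. Any claim that something is new, unique, unknown or untested is made for them only; others in the source may bear on it.

In an ADME assay on BJ cells (Homo sapiens) for cytotoxicity, with a stated time of 72 h (a higher number here means that more compound is needed for the effect, a lower number that less compound is needed), compound 2 (`C=C[C@@](C)(/C=C/c1ccc(O)c(/C=C/c2ccc(Cl)c(Cl)c2)c1)CCC=C(C)C`) gives only a limit (> 13000 nM). Compound 1 (`C=C[C@@](C)(/C=C/c1ccc(O)c(/C=C/C(=O)O)c1)CCC=C(C)C`) also gives only a limit (> 36600 nM). Compound 3 (`C=C[C@@](C)(/C=C/c1ccc(O)c(/C=C/C=C/c2ccccc2)c1)CCC=C(C)C`) carries 2-phenylethenyl in place of 3,4-dichlorophenyl on a double-bonded chain carbon bound to a double-bonded chain carbon. Within the data shown here, the only measured step (a step that the two limits leave unreadable from compound 1 to compound 2) has no readable size, so it gives no measure for this change, and no shift beyond the scatter is expected in this assay. The estimated change is small (a step that the limit leaves unreadable from compound 2 to compound 3). For compound 3 the expected value is 18000 nM with an estimated range (7000 nM to 45000 nM), and the assay may again report only a limit.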

Compound 3, half-maximal effective concentration: > 36600 nM
Compound 3: no number, only a limit; the forecaster's own chance of this, stated with the estimate: 70%; middle value at least 2.0-fold (0.30 log units) away from the limit.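

In this assay compound 3 gives only a limit, > 36600 nM, so its steps from compound 1 and from compound 2 cannot be read. The compounds shown leave open whether the exchanged groups differ at all in this assay.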